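From 2,2-Difluoroethyl to Trifluoromethyl on an Aromatic Oxygen

The source may report more compounds than this note shows. Statements on the series, on what has been measured and on what is new or still open speak of the compounds shown alone.

Of the compounds shown here, three have been measured in a physicochemical assay for lipophilicity, at pH 7.4; a lower number here means a more polar compound, a higher number a more lipophilic compound. Compound 1 `CCn1nc(CC(=O)Nc2ccc(OC(F)(F)F)c(Cl)c2)c2ccccc2c1=O` gives 5.42, compound 2 `COc1ccc(Cl)cc1NC(=O)Cc1nn(CC(=O)O)c(=O)c2ccccc12` gives 1.9, and compound 3 `O=C(O)Cn1nc(Cc2nc3cc(Cl)c(OCC(F)F)cc3[nH]2)c2ccccc2c1=O` gives 1.97. Compound 3 thus sits level with compound 2, within the scatter, and far beneath compound 1. Compound 4 `O=C(O)Cn1nc(Cc2nc3cc(Cl)c(OC(F)(F)F)cc3[nH]2)c2ccccc2c1=O` differs from compound 3 in one place: trifluoromethyl in place of 2,2-difluoroethyl on an oxygen on an aromatic ring. Among the compounds with values here, no measured pair shows this change alone. Compound 1 also carries trifluoromethoxy, but it differs from compound 3 elsewhere too, so it cannot size this step. A small rise in this assay is expected, a number 0.33 log units higher from compound 3 to compound 4 (beyond the scatter). For compound 4 the estimated value is 2.3, with an expected range of 1.9 to 2.8.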

Compound 4, distribution coefficient: 2.54
Estimate against measurement, compound 4: 0.24 log units below, and the stated range covers the measured number.
By their numbers in this assay, from the lowest: compounds 2 and 3 (each within the scatter of the next); then compound 4; then compound 1.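

In this assay, trifluoromethyl in place of 2,2-difluoroethyl on an oxygen on an aromatic ring gives a number 0.57 log units higher from compound 3 to compound 4 (beyond the scatter) and so puts a measured size on this change at this position. The number moves although each group has four heavy atoms, with one carbon traded for one fluorine. Nothing shown explains why the number moves. Going by these compounds, whether this change would give a similar step on a different core remains open, and so does the effect of an amine or a longer chain on this oxygen.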